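A few compounds are considered here, and "the series" means these few. Any claim that something is new, unique, unknown or untested is made for them only; others in the source may bear on it.

Measured so far:
compound 1 `CC(C)N1CCn2nc(-c3ccc(Cl)cc3)cc2C1=O` — 31000 nM
compound 2 `CCCCN1CCn2nc(-c3ccccc3)cc2C1=O` — > 64000 nM

Among the measured compounds shown here, in a functional assay on A549 cells (Homo sapiens) for inhibition, read by MTT assay, with a stated time of 48 h (on this read-out higher numbers stand for weaker inhibition and lower numbers for stronger inhibition), compound 1 gives 31000 nM, the only plain number here. Compound 2 reaches only (the limit of > 64000 nM in this assay, at which 1 of the 2 values shown sits), a limit of the assay rather than a number. Compound 1 therefore stands alone as a weak inhibitor. Compound 3 `COc1ccc(-c2cc3n(n2)CCN(C(C)C)C3=O)cc1` differs from it by methoxy in place of chloro on an aromatic carbon, a methoxy in place of chloro on an aromatic carbon. For the measured compounds named here, with no comparable step measured, the expected step from compound 1 to compound 3 is a 1.5-fold higher number from compound 1 to compound 3 (0.16 log units; within the scatter), toward the same or slightly weaker inhibition. Compound 3 is estimated at 45000 nM, ranging from 15000 nM to 130000 nM.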

Compound 3, half-maximal inhibitory concentration: > 64000 nM
Compound 3: only a limit was reported; the forecaster's own chance of this, stated with the estimate: 40%; middle value at least 1.4-fold (0.15 log units) from the limit.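

Replacing chloro with methoxy on an aromatic carbon, para to a large group, gives an at least 2.0-fold higher number from compound 1 to compound 3 (0.31 log units; beyond the scatter), so in this assay this position is sensitive to the change, and the direction is toward weaker inhibition. The value of compound 3 is a limit of the assay rather than a number, so the step has a known minimum but no known full size: the limit of > 64000 nM in this assay, at which 2 of the 3 values shown sit.

On these data alone, whether a bromo group or an amine at this position would match compound 1 or surpass it stays open. So does the exact strength of compound 3.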